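A few compounds are considered here, and "the series" means these few. Any claim that something is new, unique, unknown or untested is made for them only; others in the source may bear on it.

Measured in a functional assay on MGC-803 cells (Homo sapiens) for antiproliferative activity, read by CellTiter-Glo, with a stated time of 72 h; on this read-out lower numbers stand for stronger inhibition and higher numbers for weaker inhibition:

Compound 1 `O=C(NO)c1cccc(/C=C/c2ccnc(-c3cc(F)ccc3O)c2)c1`: 2710 nM
Compound 2 `O=C(NO)c1ccc(/C=C/c2ccnc(-c3cccc(CO)c3)c2)cc1`: 1740 nM

Only these two numbers are available so far. Compound 2 at 1740 nM stands within the usual scatter of compound 1 at 2710 nM, so the two cannot be ranked.

Compound 3 `Cc1ccc(-c2cc(/C=C/c3ccc(C(=O)NO)cc3)ccn2)c(F)c1`, not yet measured, keeps the core of compound 2. It carries 2-fluoro-4-methylphenyl in place of 3-(hydroxymethyl)phenyl on an aromatic carbon, next to the ring nitrogen (2-fluoro-4-methylphenyl in place of 3-(hydroxymethyl)phenyl on an aromatic carbon) .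

Among the compounds with values here, no measured pair of compounds shows what this change does, so no step beyond the scatter is expected in this assay and no direction can be called. The estimated change is a 1.1-fold lower number from compound 2 to compound 3 (0.04 log units; within the scatter), which stays within the scatter. For compound 3 the expected value is 1600 nM, with an estimated range from 500 nM to 5000 nM.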

Compound 3, half-maximal inhibitory concentration: 770 nM
The estimate for compound 3 lay 2.1-fold (0.32 log units) above the measured number; measured number inside the range.
By their numbers in this assay, from the lowest: compound 3; then compounds 2 and 1 (each within the scatter of the next).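

In this assay, putting 2-fluoro-4-methylphenyl in place of 3-(hydroxymethyl)phenyl on the aromatic carbon next to the ring nitrogen gives a 2.3-fold lower number from compound 2 to compound 3 (0.35 log units; beyond the scatter), the only step shown so far, which shows that the number at this position responds to the group placed there. Both groups have 8 heavy atoms, but the 1 hydrogen-bond donor and 1 hydrogen-bond acceptor of the leaving group are absent from the entering one, so neither is needed for the number reached by compound 3. Nothing available explains the gain. From the compounds shown here alone, because the fluorine, the methyl and the loss of the hydroxymethyl come together in one change, their separate shares stay open. Also open, going by these compounds, is how this number would respond to an aminomethyl group or a carboxylic acid on that ring.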